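The compounds below may be only part of what the source reports. "The series", "measured", "known", "first", "only" and "open" are said of these compounds alone.

Three compounds share a core and differ only in the substituents on the right-hand part of that core. In a functional assay on cells for agonist activity at Free fatty acid receptor 1 (Rattus norvegicus), read by FLIPR and calcium flux (on this read-out lower numbers stand for an effect already at smaller amounts and higher numbers for an effect only at larger amounts of compound), compound 1 `CC#C[C@@H](Cc1nnn[nH]1)c1ccc(OCc2ccc3sc(F)c(-c4ccccc4C)c3c2)cc1` gives 14 nM, and compound 3 `CC#C[C@@H](Cc1nnn[nH]1)c1ccc(OCc2ccc3scc(-c4cncnc4C)c3c2)cc1` gives 18 nM. Compound 2 `CC#C[C@@H](Cc1nnn[nH]1)c1ccc(OCc2cc(Cl)c3scc(-c4ccccc4C)c3c2)cc1` gives 108 nM in this assay, the highest of the three numbers; both other compounds lie clearly lower, beyond the scatter. Compound 4 `CC#C[C@@H](Cc1nnn[nH]1)c1ccc(OCc2cc(C)c3scc(-c4ccccc4C)c3c2)cc1` is not yet measured. It differs from compound 2 by methyl in place of chloro on an aromatic carbon. Among the measured compounds shown here, no measured pair shows this exact change, so the step in this assay is open; a modest move toward a lower number is expected, the step from compound 2 to compound 4 being estimated at a 1.5-fold lower number from compound 2 to compound 4 (0.19 log units; within the scatter). For compound 4 the estimate is 70 nM, within a range from 25 nM to 250 nM.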

Compound 4, half-maximal effective concentration: 213 nM
Beside the measured number, compound 4's estimate is 3.0-fold (0.48 log units) below it; low and high end bracket the measured number.
By their numbers in this assay, from the lowest: compounds 1 and 3 (each within the scatter of the next); then compounds 2 and 4 (each within the scatter of the next).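

In this assay, the change of chloro to methyl on this aromatic carbon gives a 2.0-fold higher number from compound 2 to compound 4 (0.29 log units; within the scatter), so the two groups cannot be told apart at this position. Among the compounds shown here, this is the first pair that differs in one place, and it shows that this exchange of one heavy atom for another leaves the read-out within the scatter. Nothing available explains this result. Still open, as far as these compounds go, is how a bare hydrogen at this carbon would compare with chloro and methyl. Also open, from the compounds shown here alone, is whether a methoxy, an amine or a longer chain there would give a number beyond the scatter.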